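Benzyl Replaces Isopropyl on the Aromatic Nitrogen

The source may hold more compounds than are shown below. What is called first, only, known or untested is meant among the compounds shown, and "the series" means these compounds.

Among the compounds with values here, compound 1 `Cc1nc(-c2ccc3c(c2)c(C#N)cn3C(C)C)sc1C(=O)O` stands highest of the three compounds measured so far: in a functional assay on the whole organism (strain Sprague-Dawley) for inhibition, with Rattus norvegicus as the target, with a stated time of 1 h, at a dose of 10 mg/kg by the oral route (a lower number here means less inhibition, a higher number more inhibition at the dose given (going by the name of the read-out)), compound 1 gives 60%. Compound 2 `CC(=O)NCCn1cc(C#N)c2cc(-c3nc(C)c(C(=O)O)s3)ccc21` gives 0% in this assay, and compound 3 `Cc1nc(-c2ccc3c(c2)c(C#N)cn3CCNS(C)(=O)=O)sc1C(=O)O` gives 0%. Both changes away from compound 1 lower the number by a large amount, a number 60 percentage points lower from compound 1 to compound 2 (beyond the scatter) and a number 60 percentage points lower from compound 1 to compound 3 (beyond the scatter), while between the two other compounds there is no change at the digits printed from compound 2 to compound 3 (within the scatter).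

Compound 4 `Cc1nc(-c2ccc3c(c2)c(C#N)cn3Cc2ccccc2)sc1C(=O)O` differs from compound 1 by benzyl in place of isopropyl on an aromatic nitrogen. The two measured steps at this nitrogen both introduced an ethyl chain bearing an acetamido or methanesulfonamido group, each with hydrogen-bond donors and acceptors, and both were large losses. The benzyl that enters here carries no donor or acceptor, so those steps bear on the change only in showing that the aromatic nitrogen does not accept every replacement of isopropyl; whether it accepts a benzyl is not told by them. A loss in this assay is therefore expected, but a smaller one than the two measured. Compound 4 is expected to give about 40%, within a range from 5% to 75%. The expected step of a number 20 percentage points lower from compound 1 to compound 4 (beyond the scatter) is thus a moderate decline rather than a complete loss.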

Compound 4, a percentage reported as inhibition, in the whole organism at one dose (the size of the read-out at that dose, not a potency): 10%
Beside the measured number, compound 4's estimate is 30 percentage points above it; the measured number falls inside the stated range.
By their numbers in this assay, from the lowest: compounds 2, 3 and 4 (each within the scatter of the next); then compound 1.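

In this assay, within the data shown here, the change to benzyl is a large loss as well, a number 50 percentage points lower from compound 1 to compound 4 (beyond the scatter) and so a replacement of isopropyl with no hydrogen-bond donor or acceptor also fails to keep the number, which the earlier compounds could not show, since both of their replacements carried such groups. Benzyl also does not separate from the two amide-type chains on this aromatic nitrogen, with a number 10 percentage points higher from compound 3 to compound 4 (within the scatter) and a number 10 percentage points higher from compound 2 to compound 4 (within the scatter) so that the three replacements cannot be ordered among themselves, and isopropyl alone stands clear of the others among these compounds. Nothing at hand explains why the number falls with benzyl on this nitrogen.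

Left open is whether a small alkyl group such as ethyl, cyclopropyl or tert-butyl on the aromatic nitrogen would stand closer to compound 1 than the benzyl of compound 4 does. Also open, going by these compounds, is how a plain 2-aminoethyl chain, or a benzyl bearing a fluorine or a methoxy group on its ring, would read at this dose.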